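The compounds below may be only part of what the source reports. "The series", "measured", "known", "first", "only" and "open" are said of these compounds alone.

Measured compounds:
- compound 1 `O=c1c(CSC(=S)N2CCCC2)coc2ccccc12`: 6000 nM
- compound 2 `Cc1ccc2c(=O)c(CSC(=S)N3CCCC3)coc2c1`: 3400 nM
- compound 3 `O=c1c(CSC(=S)N2CCCCC2)coc2cc(Cl)ccc12`: 850 nM

In a functional assay on LM7 cells (Homo sapiens) for antiproliferative activity, read by MTT assay, with a stated time of 72 h (a higher number here means a weaker inhibitor, a lower number a stronger inhibitor), compound 3 gives the lowest number of the three, and its gap to compound 2 and to compound 1 lies beyond the usual scatter in each case, so it stands as the strongest inhibitor in this set. For the measured compounds named here, the one single-point step measured so far is a 1.8-fold lower number from compound 1 to compound 2 (0.25 log units; within the scatter), a methyl in place of hydrogen on an aromatic carbon, which does not leave the scatter. Compound 4 `O=c1c(CSC(=S)N2CCCC2)coc2cc(Cl)ccc12` differs from compound 3 by pyrrolidin-1-yl in place of piperidin-1-yl on a thiocarbonyl carbon. Going by the values given here, no measured pair isolates this exchange of one ring for the other, and compound 1 and compound 2, which carry the entering pyrrolidin-1-yl, differ from compound 3 at two sites, so they give no clean reading of it. The expectation for compound 4 therefore rests on compound 3 as the closest anchor, with a step of a 1.8-fold higher number from compound 3 to compound 4 (0.25 log units; within the scatter) that is expected to stay close to the scatter and is uncertain in direction. Compound 4 is estimated at 1500 nM in this assay, with a range from 600 nM to 4000 nM.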

Compound 4, half-maximal inhibitory concentration: 2600 nM
Estimate against measurement, compound 4: 1.7-fold (0.24 log units) below; the measured number falls inside the stated range.
By their numbers in this assay, from the lowest: compound 3; then compounds 4, 2 and 1 (each within the scatter of the next, the first and the last beyond it).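

In this assay the exchange on the thiocarbonyl carbon is now isolated, and it shows a 3.1-fold higher number from compound 3 to compound 4 (0.49 log units; beyond the scatter), so at this place the ring size matters with the chloro-bearing core. With pyrrolidin-1-yl held fixed, adding chloro to the core gives a 2.3-fold lower number from compound 1 to compound 4 (0.36 log units; beyond the scatter), a modest step, while chloro in place of methyl gives a 1.3-fold lower number from compound 2 to compound 4 (0.12 log units; within the scatter), which leaves those two groups unseparated. Nothing offered here accounts for the difference between the two rings.

Piperidin-1-yl appears only together with chloro, so the compounds shown leave open whether the same step holds with methyl or hydrogen on the aromatic carbon. They also leave open how a morpholin-4-yl ring or an open-chain diethylamino group would read on the thiocarbonyl carbon.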